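Thiosugar nucleoside analogues: cytotoxicity in cultured cells

The compounds below may be only part of what the source reports. "The series", "measured", "known", "first", "only" and "open" are said of these compounds alone.

Measured compounds:
compound 1 `Cc1nn([C@H]2C[C@H](O)[C@@H](CO)S2)c(=O)[nH]c1=S`, > 40000 nM
compound 2 `CCc1nn([C@H]2C[C@H](O)[C@@H](CO)S2)c(=O)nc1O`, > 40000 nM
compound 3 `CCCc1nn([C@H]2C[C@H](O)[C@@H](CO)S2)c(=O)[nH]c1=O`, > 40000 nM

In an ADME assay on HEL cells (Homo sapiens) for cytotoxicity, read by microscopy (on this read-out higher numbers stand for lower toxicity in this test and lower numbers for higher toxicity in this test), compound 1 gives > 40000 nM, which is a limit of the assay rather than a number. In this assay compound 2 likewise gives > 40000 nM, a limit. In this assay compound 3 gives > 40000 nM, again a limit. So compound 2 stands where every member of the series so far stands: at the limit of > 40000 nM in this assay, at which 3 of the 3 values shown sit, with no number separating any of the three.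

Compound 4 `Cc1nn([C@H]2C[C@H](O)[C@@H](CO)S2)c(=O)nc1O` is to be measured next. It differs from compound 2 in one place: hydrogen in place of methyl on a saturated chain carbon bound to an aromatic carbon. Among the measured compounds shown here, since no two measured compounds give a step with actual numbers, no measured step can guide the size of this one. The step from compound 2 to compound 4 is expected to be none beyond the scatter, a number no higher from compound 2 to compound 4 (the limit leaves the size open), with the result most likely to be reported as a limit again. Compound 4 is estimated at 40000 nM, in a range from 20000 nM to 80000 nM.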

Compound 4, minimum cytotoxic concentration: > 200000 nM
Compound 4: a limit, no number (the forecaster's own chance of this, stated with the estimate: 90%); middle value at least 5.0-fold (0.69 log units) from the limit.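

In this assay compound 4 gives > 200000 nM, a limit. Compound 2 gives > 40000 nM, also a limit, so no step can be read between compound 2 and compound 4. The compounds shown leave open whether hydrogen in place of methyl changes this read-out at all.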